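A few compounds are considered here, and "the series" means these few. Any claim that something is new, unique, unknown or untested is made for them only; others in the source may bear on it.

Three compounds carry the same dienone-linked core with the triazole-coumarin ether, and differ only in the aromatic ring at the far end of the chain. Compound 1 `COc1ccccc1/C=C/C(=O)/C=C/c1ccc(OCc2cn(CCOc3cc(=O)oc4ccccc34)nn2)c(OC)c1` gives 75% in a functional assay on THP-1 cells (Homo sapiens) for inhibition, read by sulforhodamine B assay, with a stated time of 48 h, tested at 50 uM; on this read-out lower numbers stand for less inhibition of growth and higher numbers for more inhibition of growth at the one concentration tested. Compound 2 `COc1cc(/C=C/C(=O)/C=C/c2cc(OC)c(OC)c(OC)c2)ccc1OCc1cn(CCOc2cc(=O)oc3ccccc23)nn1` gives 99% in the same assay, and compound 3 `COc1ccc(/C=C/C(=O)/C=C/c2ccc(OCc3cn(CCOc4cc(=O)oc5ccccc45)nn3)c(OC)c2)cc1OC` gives 90%. Compound 3 thus stands second highest of the three numbers; the step of a number 9 percentage points lower from compound 2 to compound 3 (within the scatter) lies within the scatter, while the step of a number 15 percentage points higher from compound 1 to compound 3 (beyond the scatter) and the step of a number 24 percentage points higher from compound 1 to compound 2 (beyond the scatter) both lie beyond it.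

Compound 4 `COc1ccc(/C=C/C(=O)/C=C/c2ccc(OCc3cn(CCOc4cc(=O)oc5ccccc45)nn3)c(OC)c2)cc1` has not yet been measured. The change from compound 3 to compound 4 is hydrogen in place of methoxy on an aromatic carbon, cutting 3,4-dimethoxyphenyl back to 4-methoxyphenyl.

Going by the values given here, the closest precedent is the step of a number 9 percentage points lower from compound 2 to compound 3 (within the scatter), the same kind of change, hydrogen in place of methoxy on an aromatic carbon, which moved the number only within the scatter. Against that, compound 1, which also carries a single methoxy, gave 75%, a number clearly below compound 3. Taken together, a small decrease, at most modest, is expected, a number 8 percentage points lower from compound 3 to compound 4 (within the scatter). Compound 4 is therefore estimated to give 82% in this assay, with a range from 66% to 95%.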

Compound 4, percent growth inhibition at one concentration: 78%
Estimate against measurement, compound 4: 4 percentage points above; the range from low to high includes it.
By their numbers in this assay, from the lowest: compounds 1 and 4 (each within the scatter of the next); then compounds 3 and 2 (each within the scatter of the next).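

In this assay, hydrogen in place of methoxy ortho to a methoxy group now gives a step beyond the scatter, a number 12 percentage points lower from compound 3 to compound 4 (beyond the scatter), whereas the earlier change of the same kind, a number 9 percentage points lower from compound 2 to compound 3 (within the scatter), stayed within it; taking 3,4,5-trimethoxyphenyl all the way back to 4-methoxyphenyl gives a larger step, a number 21 percentage points lower from compound 2 to compound 4 (beyond the scatter), so among these compounds, extra methoxy groups on this ring go with more inhibition of growth. The single methoxy, however, gives no readable difference between 2-methoxyphenyl and 4-methoxyphenyl, a number 3 percentage points higher from compound 1 to compound 4 (within the scatter), so among these compounds the count of methoxy groups is what separates the numbers, not where the lone methoxy sits. Nothing given here explains why these steps take the sizes they do.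

As far as these compounds go, what remains open is how a hydroxy group, a fluorine or an amine would read on this ring in place of a methoxy, and how an unsubstituted phenyl would compare with compound 4. The numbers also come from a single concentration, so they leave open whether the same order would hold at lower concentrations, where compound 2 and compound 3 might separate.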